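Swapping a halogen on the phenoxy ring of compound 3

The compounds below may be only part of what the source reports. "The series", "measured", "known", "first", "only" and "open" are said of these compounds alone.

Of the compounds shown here, three sharing one core have been measured in an assay on HEK293 cells for inhibition of Voltage-dependent T-type calcium channel subunit alpha-1G (Homo sapiens), read by patch clamp, tested at 10 uM; a lower number here means less inhibition, a higher number more inhibition at the concentration tested (going by the name of the read-out). Compound 1 `O[C@H](COc1ccc(C(F)(F)F)cc1)CN1CCN(c2ccccc2F)CC1` gives 48.9% in this assay. Compound 2 `COc1ccccc1N1CCN(C[C@H](O)COc2ccc(Cl)cc2)CC1` gives 48.8% in this assay. Compound 3 `O[C@@H](COc1ccc(F)cc1)CN1CCN(c2ccc(F)cc2)CC1` gives 47.5% in this assay. The number of compound 3 sits within the usual scatter of both the number of compound 1 and the number of compound 2, so the three compounds cannot be told apart on these measurements.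

Compound 4 `O[C@@H](COc1ccc(Cl)cc1)CN1CCN(c2ccc(F)cc2)CC1` has not yet been measured. It differs from compound 3 in one place: chloro in place of fluoro on an aromatic carbon. Compound 2 also carries a chloro at that place, though it differs from compound 3 elsewhere as well. In this assay compound 2 gives 48.8%, which is within the scatter of the number of compound 3. On that basis the step of a number 1.5 percentage points higher from compound 3 to compound 4 (within the scatter) is expected to be none beyond the scatter. For compound 4 the expected value in this assay is 49%, with a likely range from 38% to 60%.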

Compound 4, a percentage reported as inhibition, at one concentration (the size of the read-out at that concentration, not a potency): 39.7%
Estimate against measurement, compound 4: 9.3 percentage points above; measured number inside the range.
By their numbers in this assay, from the lowest: compounds 4, 3, 2 and 1 (each within the scatter of the next).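

For the compounds shown here, compound 3 and compound 4 form the first pair here that differs in one place, so they give the first direct reading of the change from 4-fluorophenoxy to 4-chlorophenoxy in this assay. That pair reads a number 7.8 percentage points lower from compound 3 to compound 4 (within the scatter), so on this one swap fluoro and chloro cannot be told apart at this position on the aromatic ring. No measurement shown bears on why the pair reads as it does.

On these data alone, it remains open whether a group of another kind at this place, such as an amine or a carboxylic acid, would move the number beyond the scatter. As far as these compounds go, it is also open whether the same swap from fluoro to chloro on the 4-fluorophenyl group, on the other side of the shared core, would read the same way.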